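Adding a methoxy group to compound 2

A few compounds are considered here, and "the series" means these few. Any claim that something is new, unique, unknown or untested is made for them only; others in the source may bear on it.

- Compound 1 `O=C(Nc1ccc(Sc2nc3ccccc3s2)c(Cl)c1)c1cc(Br)cc(Br)c1`: > 100000 nM, a limit
- Compound 2 `O=C(Nc1ccc(Sc2nc3ccccc3s2)cc1)c1cc(Br)cc(Br)c1`: > 100000 nM, a limit
- Compound 3 `O=C(Nc1ccc(Sc2nc3ccccc3s2)cc1)c1ccccc1O`: 74000 nM

In an ADME assay on HEK293 cells (Homo sapiens) for cytotoxicity, read by reporter gene assay and resazurin assay, with a stated time of 48 h (a higher number here means that more compound is tolerated, a lower number that less compound is tolerated), compound 2 gives > 100000 nM, which is a limit and not a number. Its place is the limit of > 100000 nM in this assay, at which 2 of the 3 values shown sit. Compound 4 `COc1c(Br)cc(Br)cc1C(=O)Nc1ccc(Sc2nc3ccccc3s2)cc1` carries methoxy in place of hydrogen on an aromatic carbon, ortho to a bromo group and para to another: methoxy in place of hydrogen on an aromatic carbon. Among the compounds with values here, two measured steps touch compound 2, and neither involves methoxy. One is a step that the two limits leave unreadable from compound 1 to compound 2. The other is an at least 1.3-fold lower number from compound 2 to compound 3 (0.13 log units; that floor lies within the scatter). From these, no change beyond the scatter is expected in this assay. The estimated step is a number no higher from compound 2 to compound 4 (the limit leaves the size open). Compound 4 is expected at 100000 nM, within an estimated range of 50000 nM to 200000 nM.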

Compound 4, half-maximal cytotoxic concentration: > 100000 nM
Compound 4: no number, only a limit; the forecaster's own chance of this, stated with the estimate: 65%; the middle value sits exactly at the limit.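

No step can be read from compound 2 to compound 4 in this assay: both values are limits, not numbers. The compounds shown leave open whether methoxy in place of hydrogen on an aromatic carbon changes this read-out at all.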